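Three ring centres inverted in a small sugar-like acid

The compounds below may be only part of what the source reports. "The series", "measured", "known", "first", "only" and "open" are said of these compounds alone.

Compound 3 `O=C(O)[C@H]1NC[C@H](O)[C@@H](O)[C@@H]1O` gives 43% in an assay on isolated protein for inhibition of cytosolic endo-beta-N-acetylglucosaminidase (Homo sapiens), tested at 1000 uM (on this read-out higher numbers stand for more inhibition at the one concentration tested (going by the name of the read-out) and lower numbers for less inhibition), second highest of three numbers: compound 2 `O=C(O)[C@@H]1NC[C@@H](O)[C@H](O)[C@H]1O` gives 50%, compound 1 `O=C(O)[C@@H]1NC[C@@H](O)[C@@H](O)[C@H]1O` gives 26%. Compound 4 `O=C(O)[C@H]1NC[C@@H](O)[C@H](O)[C@H]1O` is the next step; (the two compounds have the same atoms and bonds and differ only in configuration as drawn: 3 of 4 stereo elements differ; a stereocentre at a saturated ring carbon is drawn S in compound 3 and R in compound 4; a stereocentre at a saturated ring carbon is drawn R in compound 3 and S in compound 4; a stereocentre at a saturated ring carbon is drawn R in compound 3 and S in compound 4). Steps of this kind that have already been measured are the rises a number 24 percentage points higher from compound 1 to compound 2 (beyond the scatter) and a number 17 percentage points higher from compound 1 to compound 3 (beyond the scatter), which are modest, and a number 7 percentage points lower from compound 2 to compound 3 (within the scatter), which stays within scatter. Changing configuration alone thus moves the read-out by at most a modest amount, in either direction. For compound 4 a step of a number 3 percentage points lower from compound 3 to compound 4 (within the scatter) is therefore expected, with no clear direction. Compound 4 is estimated at 40%, within 15% to 65%.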

Compound 4, a percentage reported as inhibition, at one concentration (the size of the read-out at that concentration, not a potency): 6.3%
Estimate against measurement, compound 4: 33.7 percentage points above; the whole stated range lies above it.
By their numbers in this assay, from the lowest: compound 4; then compound 1; then compounds 3 and 2 (each within the scatter of the next).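

A single inverted ring centre now gives a number 43.7 percentage points lower from compound 2 to compound 4 (beyond the scatter), whereas the earlier single inversion was only modest. Three inverted centres give a number 36.7 percentage points lower from compound 3 to compound 4 (beyond the scatter) and two give a number 19.7 percentage points lower from compound 1 to compound 4 (beyond the scatter), so among these compounds the size of a step does not follow the number of centres inverted. Configuration alone can therefore take this read-out far down: the fact that compounds 2 and 4 differ only in the configuration as drawn

From the compounds shown here alone, how a methyl ester or an amide in place of the carboxylic acid would fare on compound 2 or compound 4 stays open. A reading at one concentration also gives no potency for any of these compounds.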